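Pyridine for pyrazine on a biaryl amide

The source may hold more compounds than are shown below. What is called first, only, known or untested is meant among the compounds shown, and "the series" means these compounds.

Measured compounds:
compound 1 `CCCOc1ccc(C[C@@H](Cc2ccccc2)C(=O)O)cc1CNC(=O)c1ccc(-c2ccc(F)cc2)cc1`: < 1 ug/mL
compound 2 `CCCOc1ccc(C[C@@H](Cc2ccccc2)C(=O)O)cc1CNC(=O)c1ccc(-c2ccccc2)cc1`: < 1 ug/mL
compound 3 `CCCOc1ccc(C[C@@H](Cc2ccccc2)C(=O)O)cc1CNC(=O)c1ccc(-c2cnccn2)cc1`: 32.2 ug/mL

In a physicochemical assay for solubility, read by HPLC, in phosphate buffer, measured as thermodynamic solubility, with a stated time of 48 h, at pH 7.2 (on this read-out higher numbers stand for higher solubility and lower numbers for lower solubility), compound 1 sits at a limit of the assay, < 1 ug/mL. Compound 2 likewise gives only a limit, < 1 ug/mL. Compound 3 is the one compound with a number, 32.2 ug/mL, and so stands alone at the top of what is shown; the limit of < 1 ug/mL in this assay, at which 2 of the 3 values shown sit, marks where the other two sit.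

Compound 4 `CCCOc1ccc(C[C@@H](Cc2ccccc2)C(=O)O)cc1CNC(=O)c1ccc(-c2ccncc2)cc1` has not yet been measured in this assay. It differs from compound 3 by pyridin-4-yl in place of pyrazin-2-yl on an aromatic carbon: a six-membered aromatic ring with 1 hetero atom enters where one with 2 hetero atoms leaves. The measured steps that bear on this are an at least 32-fold higher number from compound 1 to compound 3 (1.50 log units; beyond the scatter) and an at least 32-fold higher number from compound 2 to compound 3 (1.50 log units; beyond the scatter), both large and beyond the scatter, while a step that the two limits leave unreadable from compound 1 to compound 2. Since compound 4 keeps one ring nitrogen rather than two or none, compound 4 is expected to fall below compound 3 but above the limit, with a 4.0-fold lower number from compound 3 to compound 4 (0.60 log units; beyond the scatter). The estimate for compound 4 is 8 ug/mL, between 2 ug/mL and 30 ug/mL.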

Compound 4, solubility: 34.1 ug/mL
The estimate for compound 4 lay 4.3-fold (0.63 log units) below the measured number; measured number above the stated range.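

In this assay, pyridin-4-yl and pyrazin-2-yl cannot be told apart at this position, para to a large group: the change gives a 1.1-fold higher number from compound 3 to compound 4 (0.02 log units; within the scatter), so one ring nitrogen serves here as well as two. The large step seen earlier for pyrazin-2-yl also appears for pyridin-4-yl, with an at least 34-fold higher number from compound 2 to compound 4 (1.53 log units; beyond the scatter) and an at least 34-fold higher number from compound 1 to compound 4 (1.53 log units; beyond the scatter). Compound 1 and compound 2 each give only a limit, so the true size of these two steps stays unread: the limit of < 1 ug/mL in this assay, at which 2 of the 4 values shown sit.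

The compounds shown leave open whether the ring nitrogen must sit where it does in pyridin-4-yl, as pyridin-3-yl or pyridin-2-yl could tell. They also leave open whether a phenyl ring carrying an amine or a carboxylic acid would reach the level of compound 3 and compound 4.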